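Amino Group Added to the Thiophene Ring: What to Expect

The source may hold more compounds than are shown below. What is called first, only, known or untested is meant among the compounds shown, and "the series" means these compounds.

Compound 1 `COc1ccc(-c2cc3ccccc3nc2/C=C/C(=O)c2ccc([N+](=O)[O-])cc2)cc1` gives 6100 nM in a functional assay on H184B5F5/M10 cells (Homo sapiens) for antiproliferative activity, read by XTT assay, with a stated time of 72 h; on this read-out lower numbers stand for stronger inhibition and higher numbers for weaker inhibition.
Compound 2 `COc1ccc(-c2cc3ccccc3nc2/C=C/C(=O)c2cccs2)cc1` gives 7030 nM in this assay.

Within the data shown here, compound 2 stands at 7030 nM in this assay, and its only neighbour among the measured compounds is compound 1; the step of a 1.2-fold higher number from compound 1 to compound 2 (0.06 log units; within the scatter) is within the scatter, so the two cannot be told apart on these numbers.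

Compound 3 `COc1ccc(-c2cc3ccccc3nc2/C=C/C(=O)c2sccc2N)cc1` differs from compound 2 by amino in place of hydrogen on an aromatic carbon. Among the measured compounds shown here, no measured step involves an amino group, so nothing bears directly on this change. For the measured compounds named here, the one step that is known exchanged a whole ring and still stayed within the scatter. There is therefore no ground for expecting a shift beyond the scatter in this assay for compound 3, in either direction. Compound 3 is estimated at 6000 nM, with a range from 2500 nM to 15000 nM. That estimate means an expected step of a 1.2-fold lower number from compound 2 to compound 3 (0.07 log units; within the scatter).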

Compound 3, half-maximal inhibitory concentration: > 10000 nM
Compound 3 was reported as a limit; the forecaster's own chance of this, stated with the estimate: 5%; at least 1.6-fold (0.22 log units) between middle value and limit.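

The value for compound 3 is a limit and not a number: the limit of > 10000 nM in this assay, at which 1 of the 3 values shown sits.

Putting amino on this aromatic carbon, next to the ring atom that bears a large group, gives an at least 1.4-fold higher number from compound 2 to compound 3 (0.15 log units; that floor lies within the scatter), and replacing the 4-nitrophenyl with 3-aminothiophen-2-yl gives an at least 1.6-fold higher number from compound 1 to compound 3 (0.21 log units; that floor lies within the scatter). Among these compounds, this is the first look at a change on the thiophene ring itself, and it shows that amino at this place brings no gain in inhibition, though both floors lie within the scatter, so a real loss is not established either.

Going by these compounds, how far the true value of compound 3 lies past its limit stays open. So does the question of whether a methyl group or a hydroxyl group on this same carbon would read any differently in this assay.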